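Oxime in place of ketone on a triazole thioether series

The source may hold more compounds than are shown below. What is called first, only, known or untested is meant among the compounds shown, and "the series" means these compounds.

In a functional assay on the whole organism (strain albino) for inhibition, with Rattus norvegicus as the target, read by paw edema, with a stated time of 2 h, at a dose of 0.28 mmol/kg by the oral route (a lower number here means less inhibition, a higher number more inhibition at the dose given (going by the name of the read-out)), compound 2 `C=CCn1c(SCC(=O)c2ccccc2)nnc1-c1ccc(OC)cc1` gives 53% and compound 1 `C=CCn1c(SC/C(=N/O)c2ccccc2)nnc1-c1ccc(OC)cc1` gives 66%. The change a group of 9 heavy atoms (7 carbon, 1 nitrogen, 1 oxygen; one six-membered aromatic ring of carbon only) in place of a group of 8 heavy atoms (7 carbon, 1 oxygen; one six-membered aromatic ring of carbon only), on a saturated chain carbon bound to a sulfur brings a number 13 percentage points higher from compound 2 to compound 1 (beyond the scatter). Compound 3 `CCn1c(SCC(=O)c2ccccc2)nnc1-c1cc(OC)c(OC)c(OC)c1` gives 41% in this assay, the lowest of the three numbers, with each step to the others beyond the scatter. The difference between the core of compound 2 and the core of compound 3 is not broken down here. Compound 4 `CCn1c(SC/C(=N/O)c2ccccc2)nnc1-c1cc(OC)c(OC)c(OC)c1` is not yet measured in this assay; it differs from compound 3 by a group of 9 heavy atoms (7 carbon, 1 nitrogen, 1 oxygen; one six-membered aromatic ring of carbon only) in place of a group of 8 heavy atoms (7 carbon, 1 oxygen; one six-membered aromatic ring of carbon only), on a saturated chain carbon bound to a sulfur, the same change as from compound 2 to compound 1, occurring twice among these compounds. For the measured compounds named here, the step from compound 3 to compound 4 is expected to be a number 13 percentage points higher from compound 3 to compound 4 (beyond the scatter), resting on the single earlier step of a number 13 percentage points higher from compound 2 to compound 1 (beyond the scatter) made on a different core. Compound 4 is accordingly estimated at 54% in this assay, between 40% and 68%.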

Compound 4, a percentage reported as inhibition, in the whole organism at one dose (the size of the read-out at that dose, not a potency): 67%
The estimate for compound 4 lay 13 percentage points below the measured number; measured number inside the range.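

In this assay, replacing the benzoyl group with the oxime group gives a number 26 percentage points higher from compound 3 to compound 4 (beyond the scatter). The change points the same way on both cores, and the sizes of the two steps do not differ beyond the scatter: the same change on two cores in this assay, a number 13 percentage points higher (beyond the scatter) from compound 2 to compound 1 and a number 26 percentage points higher (beyond the scatter) from compound 3 to compound 4, 13 percentage points apart, within the scatter of two such steps This supports carrying the change between these two cores, but two pairs at a single dose and time give no potency and do not show that it will hold on any other core.

The compounds shown leave open whether the step persists on a core carrying an amine, a carboxylic acid or a longer chain. They also leave open how each of the differences between the two cores contributes on its own.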